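A Dimethylamino Swap Examined for Fibroblast Cytotoxicity

This account rests on a few compounds, and the source may have more. Where it says the series, first, only, none or still open, it means among the compounds named here.

Compound 1 `CC(C)OC(=O)c1ccc(NCc2cncn2Cc2ccc(-c3ccccc3)cc2)cc1-c1ccccc1` gives > 10000 nM in a toxicity assay on NIH3T3 cells (Mus musculus) for cytotoxicity, read by resazurin assay (a higher number here means that more compound is needed for the effect, a lower number that less compound is needed), a limit of the assay.
Compound 2 `Cc1cccc(-c2cc(NCc3cncn3Cc3ccc(-c4ccccc4)cc3)ccc2-c2nc3ccccc3s2)c1C` gives > 1000 nM in this assay, also a limit.
Compound 3 `COC(=O)c1ccc(NCc2cncn2Cc2ccccc2[N+](=O)[O-])cc1-c1ccccc1` gives 10000 nM in this assay.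

Compound 1 therefore stands at a limit rather than a number, at the limit of > 10000 nM in this assay, at which 1 of the 3 values shown sits, while compound 2 sits at the limit of > 1000 nM in this assay, at which 1 of the 3 values shown sits; only compound 3 carries a measured value, and it lies close to where compound 1 is capped. Going by the values given here, no step between measured compounds is available.

Compound 4 `CN(C)c1ccc(NCc2cncn2Cc2ccc(-c3ccccc3)cc2)cc1-c1ccccc1` differs from compound 1 by dimethylamino in place of isopropoxycarbonyl on an aromatic carbon. The step from compound 1 to compound 4 is expected to be small, a number no higher from compound 1 to compound 4 (the limit leaves the size open), not beyond the scatter in either direction. Compound 4 is thus estimated at 10000 nM, between 3000 nM and 30000 nM, with a real chance that this assay again reports only a limit.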

Compound 4, half-maximal effective concentration: > 1000 nM
Compound 4 was reported as a limit (the forecaster's own chance of this, stated with the estimate: 55%); the middle value is on the limit's open side.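

In this assay compound 4 gives > 1000 nM, a limit. Going by these compounds alone, compound 1 gives > 10000 nM, also a limit, so no step between compound 1 and compound 4 can be read. The compounds shown leave open whether dimethylamino in place of isopropoxycarbonyl changes the concentration needed at all.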